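The compounds below may be only part of what the source reports. "The series", "measured", "known", "first", "only" and "open" are said of these compounds alone.

Three compounds share one core and differ only in the group sitting on a nitrogen on an aromatic ring. In an assay on isolated protein for inhibition of Amine oxidase [flavin-containing] B (Homo sapiens), read by spectrophotometry (a higher number here means a weaker inhibitor, a lower number a stronger inhibitor), compound 1 `Clc1ccccc1/C=N/Nc1nc2ccccc2nc1Cc1ccccc1` gives 87000 nM, compound 2 `Oc1ccc(/C=N/Nc2nc3ccccc3nc2Cc2ccccc2)cc1` gives 7900000 nM, and compound 3 `C/C(=N\Nc1nc2ccccc2nc1Cc1ccccc1)c1ccccn1` gives 980000 nM. Compound 3 thus stands second highest of the three: nearest is an 8.1-fold lower number from compound 2 to compound 3 (0.91 log units; beyond the scatter), furthest is an 11-fold higher number from compound 1 to compound 3 (1.05 log units; beyond the scatter). Compound 4 `C=NNc1nc2ccccc2nc1Cc1ccccc1` goes further and carries a group of 2 heavy atoms (1 carbon, 1 nitrogen; no ring) in place of a group of 9 heavy atoms (7 carbon, 2 nitrogen; one six-membered aromatic ring with 1 hetero atom), on a nitrogen on an aromatic ring. Among the compounds with values here, no measured step removes the ring entirely; the steps of an 11-fold higher number from compound 1 to compound 3 (1.05 log units; beyond the scatter) and a 91-fold higher number from compound 1 to compound 2 (1.96 log units; beyond the scatter) only swap one ring for another, yet each moved the number by a large amount. Losing the ring is expected to weaken inhibition, an estimated 3.1-fold higher number from compound 3 to compound 4 (0.49 log units; beyond the scatter). Compound 4 is expected to give 3000000 nM, with a range from 500000 nM to 20000000 nM.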

Compound 4, half-maximal inhibitory concentration: 950000 nM
For compound 4 the middle estimate is 3.2-fold (0.50 log units) above the measured one, within the range that was stated.
By their numbers in this assay, from the lowest: compound 1; then compounds 4 and 3 (each within the scatter of the next); then compound 2.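

In this assay, a ring in the group on a nitrogen on an aromatic ring is not needed to reach the level of compound 3, since the two-atom group of compound 4 stands level with it (a 1.0-fold lower number from compound 3 to compound 4 (0.01 log units; within the scatter)). Ring groups can still fall on either side of the ringless one: (an 11-fold higher number from compound 1 to compound 4 (1.04 log units; beyond the scatter)) favours the ring of compound 1, while (an 8.3-fold lower number from compound 2 to compound 4 (0.92 log units; beyond the scatter)) favours the ringless group over the ring of compound 2. Nothing available explains these differences. Still open, going by these compounds, is how a simple amine or a longer carbon chain in this place would compare.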